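The source may hold more compounds than are shown below. What is called first, only, known or untested is meant among the compounds shown, and "the series" means these compounds.

Working notes on the dichloroacetamide anilide series. Compound 1 `COc1ccc(-c2cc(NC(=O)C(Cl)Cl)cc(-c3ccc(OC)c(F)c3)c2)cc1F` and compound 2 `CCOc1ccccc1-c1cc(NC(=O)C(Cl)Cl)cc(-c2ccccc2OCC)c1` share the core with compound 3 `O=C(Nc1cccc(-c2ccc(-c3ccccc3)cc2)c1)C(Cl)Cl`; in a functional assay on A549 cells (Homo sapiens) for cytotoxicity, read by MTT assay, with a stated time of 68 h (a higher number here means a weaker inhibitor, a lower number a stronger inhibitor), compound 1 gives 1950 nM and compound 2 gives 7280 nM. In this assay compound 3 gives > 50000 nM, which is a limit of the assay and not a number. For the measured compounds named here, compound 3 therefore stands at the weak end of the values shown, the single value sitting at the limit being that noted in the limit of > 50000 nM in this assay, at which 1 of the 3 values shown sits. Compound 4 `O=C(Nc1cccc(-c2ccccc2)c1)C(Cl)Cl` has not been measured in this assay. It differs from compound 3 by hydrogen in place of phenyl on an aromatic carbon. With compound 3 already at a limit, no step beyond the scatter is expected in this assay from this change, and the expected step is a step that the limit leaves unreadable from compound 3 to compound 4. Compound 4 is expected near 70000 nM, within 20000 nM to 250000 nM, most probably again reported only as a limit.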

Compound 4, half-maximal inhibitory concentration: 8900 nM
For compound 4 the middle estimate is 7.9-fold (0.90 log units) above the measured one; the whole stated range lies above it.
By their numbers in this assay, from the lowest: compound 1; then compounds 2 and 4 (each within the scatter of the next). At a limit, above all of these: compound 3.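

In this assay, hydrogen in place of phenyl gives an at least 5.6-fold lower number from compound 3 to compound 4 (0.74 log units; beyond the scatter). For the compounds shown here, this is the first comparison that differs in one place, and it shows that this aromatic carbon, para to a large group, is sensitive to the change, with phenyl there going with the weaker reading. The reading for compound 3 is a limit and not a number, so the step gives only a minimum size: the limit of > 50000 nM in this assay, at which 1 of the 4 values shown sits.

Going by these compounds, what an amine or a carboxylic acid on this aromatic carbon would give remains open. So does whether the same change would act alike on the core of compound 1 or compound 2.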